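Working notes: from compound 1 to compound 4

This account rests on a few compounds, and the source may have more. Where it says the series, first, only, none or still open, it means among the compounds named here.

In an ADME assay on microsomes from liver (Homo sapiens) for metabolic stability (a lower number here means that the compound disappears faster, a higher number that the compound lasts longer), compound 1 `COc1cc(OCc2cccc(-c3cnc(OC)nc3)c2)c2cc(-c3cn4nc(OC)sc4n3)oc2c1` gives 0.6 h, the lower of the two actual numbers in the series. Compound 2 `COc1cc(OCc2csc(-c3ccc(S(C)(=O)=O)cc3)n2)c2cc(-c3cn4nc(OC)sc4n3)oc2c1` gives 1.22 h, the nearest number, and its gap to compound 1 lies beyond the scatter. Compound 3 `COc1cc(OCc2csc(-c3ccc(C(=O)O)cc3)n2)c2cc(-c3cn4nc(OC)sc4n3)oc2c1` gives > 2 h, which is a limit and not a number.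

Compound 4 `COc1cc(OCc2cccc(-c3ccc(C#N)cc3)c2)c2cc(-c3cn4nc(OC)sc4n3)oc2c1` is still unmeasured. It carries 4-cyanophenyl in place of 2-methoxypyrimidin-5-yl on an aromatic carbon, meta to a large group: 4-cyanophenyl in place of 2-methoxypyrimidin-5-yl on an aromatic carbon.

Among the compounds with values here, the only measured step is an at least 1.6-fold higher number from compound 2 to compound 3 (0.21 log units; that floor lies within the scatter), with carboxy in place of methylsulfonyl on an aromatic carbon. It rests on (the limit of > 2 h in this assay, at which 1 of the 3 values shown sits), and its floor lies within the scatter. Within the data shown here, it involves neither group exchanged in compound 4, so it offers no size to carry over, and no measured step makes the exchange itself.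

The expectation therefore stays anchored on compound 1 at 0.6 h, and no step beyond the scatter is expected in this assay. The expected step is a 1.2-fold higher number from compound 1 to compound 4 (0.07 log units; within the scatter), with no firm direction implied. For compound 4 the estimated half-life is 0.7 h, with an expected range of 0.35 h to 1.4 h.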

Compound 4, half-life: > 2 h
Compound 4: no number, only a limit (the forecaster's own chance of this, stated with the estimate: 3%); at least 2.8-fold (0.45 log units) between middle value and limit.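

Within the data shown here, on the aromatic carbon meta to a large group, the group carried there proves able to move the half-life beyond the scatter, which the earlier compounds could not show, since their only measured step lay elsewhere and its floor stayed within the scatter: an at least 3.3-fold higher number from compound 1 to compound 4 (0.52 log units; beyond the scatter) with 4-cyanophenyl in place of 2-methoxypyrimidin-5-yl. The two groups are alike in being single six-membered aromatic rings with the same heavy-atom count and no net charge, so the step comes from an exchange that keeps that count and changes the ring from one with two hetero atoms to one of carbon only, with a nitrile added. In this assay compound 4 gives > 2 h, which is a limit and not a number, so the step has a floor and no measured size: the limit of > 2 h in this assay, at which 2 of the 4 values shown sit.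

The compounds shown do not separate the part played by the nitrile from the part played by the two ring nitrogens that leave, and an unsubstituted phenyl or a 4-cyanopyridinyl group at this place would pull the two apart. As far as these compounds go, how far the half-life of compound 4 actually lies beyond its limit also stays open.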